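The source may report more compounds than this note shows. Statements on the series, on what has been measured and on what is new or still open speak of the compounds shown alone.

Measured so far:
- compound 1, `Cn1nnnc1SCC(=O)N/N=C/c1ccccc1[N+](=O)[O-]`: 2020000 nM
- compound 2, `Cn1nnnc1SCC(=O)N/N=C/c1ccccc1O`: limit, > 10000000 nM
- compound 3, `COc1ccccc1/C=N/NC(=O)CSc1nnnn1C`: 3160000 nM

In an ADME assay on NIH3T3 cells (Mus musculus) for cytotoxicity, read by XTT assay, with a stated time of 24 h (on this read-out lower numbers stand for stronger inhibition and higher numbers for weaker inhibition), compound 1 gives 2020000 nM. Compound 2 reaches only the limit of the read-out, > 10000000 nM, which is a limit and not a number; see (the limit of > 10000000 nM in this assay, at which 1 of the 3 values shown sits). Compound 3 gives 3160000 nM in this assay and thus holds the highest of the two numbers, its nearest neighbour being compound 1, with a 1.6-fold higher number from compound 1 to compound 3 (0.19 log units; within the scatter).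

The next compound, compound 4, `Cc1ccccc1/C=N/NC(=O)CSc1nnnn1C`, differs from compound 3 by methyl in place of methoxy on an aromatic carbon.

Among the measured compounds shown here, no measured step exchanges methyl for methoxy directly. For the measured compounds named here, two steps touch the same position: a 1.6-fold higher number from compound 1 to compound 3 (0.19 log units; within the scatter), and an at least 4.9-fold higher number from compound 1 to compound 2 (0.69 log units; beyond the scatter). The step of an at least 3.1-fold lower number from compound 2 to compound 3 (0.50 log units; beyond the scatter) shows that removing the hydrogen from the oxygen brings the number back from the limit. Swapping methoxy for methyl gives no clear pointer from these; the expectation is therefore a step of about a 1.1-fold lower number from compound 3 to compound 4 (0.02 log units; within the scatter), that is, no change beyond the scatter. Compound 4 is accordingly estimated at 3000000 nM in this assay, within 1000000 nM to 10000000 nM.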

Compound 4, half-maximal inhibitory concentration: 6320000 nM
The estimate for compound 4 lay 2.1-fold (0.32 log units) below the measured number; the measured number falls inside the stated range.
By their numbers in this assay, from the lowest: compounds 1, 3 and 4 (each within the scatter of the next, the first and the last beyond it). At a limit, above all of these: compound 2.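

In this assay, the aromatic carbon ortho to a large group now carries methyl, and this separates clearly from nitro: a 3.1-fold higher number from compound 1 to compound 4 (0.50 log units; beyond the scatter). Methyl in place of methoxy gives a 2.0-fold higher number from compound 3 to compound 4 (0.30 log units; within the scatter), so the two groups cannot be told apart here even though methoxy counts a hydrogen-bond acceptor and methyl does not, and compounds 1, 3 and 4 form a run in which only the two ends lie beyond the scatter of each other. Methyl in place of hydroxy gives an at least 1.5-fold lower number from compound 2 to compound 4 (0.19 log units; that floor lies within the scatter), a floor that does not separate the two compounds, with compound 2 still a limit and not a number: the limit of > 10000000 nM in this assay, at which 1 of the 4 values shown sits.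

On these data alone, what an amine or a carboxylic acid on this carbon would do remains open, as does whether a longer chain such as ethyl or ethoxy would stay within the scatter of compound 4. The compounds shown vary in this one place only, so the effect of a group elsewhere on the aromatic ring, or of a change in the shared core, also remains open.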